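Imidazole for aminothiazole on the shared core

The compounds below may be only part of what the source reports. "The series", "measured", "known", "first", "only" and "open" are said of these compounds alone.

Compound 3 `CC(C)C(c1cnc(N)s1)c1ccc(-c2ccc3cccc(F)c3c2)[nH]c1=O` gives 0.0983 h in an ADME assay on microsomes from liver (Rattus norvegicus) for metabolic stability (on this read-out higher numbers stand for a longer-lived compound and lower numbers for a shorter-lived compound), the lowest of the two numbers shown; its nearest neighbour is compound 2 `CC(C)C(c1ccc(-c2ccc3cccc(F)c3c2)[nH]c1=O)N1CCCCC1=O` with 0.102 h, and the step of a 1.0-fold lower number from compound 2 to compound 3 (0.02 log units; within the scatter) lies within the scatter. Compound 1 `CCn1ncc2c(F)cc(-c3ccc(C(CC)(CC)c4nncn4C)c(=O)[nH]3)cc21` is reported only as a limit, > 3 h, which is the limit of > 3 h in this assay, at which 1 of the 3 values shown sits. Compound 4 `Cc1c[nH]c(C(c2ccc(-c3ccc4cccc(F)c4c3)[nH]c2=O)C(C)C)n1` differs from compound 3 by 4-methyl-1H-imidazol-2-yl in place of 2-amino-1,3-thiazol-5-yl on a saturated chain carbon bound to an aromatic carbon and a saturated chain carbon. For the measured compounds named here, the only measured step that bears on this change is a 1.0-fold lower number from compound 2 to compound 3 (0.02 log units; within the scatter), an exchange of the group at the same place that left the number essentially unchanged, so no step beyond the scatter is expected here. Compound 4 is therefore expected to show a step of a 1.0-fold higher number from compound 3 to compound 4 (0.01 log units; within the scatter), that is an estimated 0.1 h with a range from 0.04 h to 0.3 h.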

Compound 4, half-life: < 0.0667 h
Compound 4 gave a limit, no number; the forecaster's own chance of this, stated with the estimate: 0%; middle value at least 1.4-fold (0.17 log units) away from the limit.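

Compound 4 yields a limit rather than a number: the limit of < 0.0667 h in this assay, at which 1 of the 4 values shown sits. Even so, 4-methyl-1H-imidazol-2-yl, a third group at this saturated chain carbon, gives an at least 1.4-fold lower number from compound 3 to compound 4 (0.16 log units; that floor lies within the scatter) and an at least 1.5-fold lower number from compound 2 to compound 4 (0.18 log units; that floor lies within the scatter). Neither floor goes beyond the scatter, so the three groups cannot yet be told apart, but this new group gives no sign of a longer-lived compound.

As far as these compounds go, how far compound 4 lies past its limit remains open. So does whether an amine or a carboxylic acid at this place on the shared core would give a longer half-life.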